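This account rests on a few compounds, and the source may have more. Where it says the series, first, only, none or still open, it means among the compounds named here.

Measured so far:
- compound 1 `O=C(Nc1cccc(-n2cc(-c3ccncc3)c(-c3cc(O)cc(Cl)c3)n2)c1)Nc1ccc(Cl)c(C(F)(F)F)c1`: 102%
- compound 2 `O=C(Nc1cccc(-n2cc(-c3ccncc3)c(-c3cc(O)cc(Cl)c3)n2)c1)Nc1ccc(Cl)c(Cl)c1`: 106%

Going by the values given here, in a functional assay on COLO 205 cells (Homo sapiens) for inhibition, read by sulforhodamine B assay, with a stated time of 48 h, tested at 0.01 uM (on this read-out higher numbers stand for a weaker effect at the one concentration tested and lower numbers for a stronger effect), compound 1 stands as the lowest of the two numbers, and the only neighbour is given by the step of a number 4 percentage points higher from compound 1 to compound 2 (within the scatter), which lies within the scatter. Both numbers sit at a level that shows no effect at the single concentration tested, so neither compound can be set apart from the other.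

The next compound, compound 3 `COc1cc(Cl)cc(-c2nn(-c3cccc(NC(=O)Nc4ccc(Cl)c(C(F)(F)F)c4)c3)cc2-c2ccncc2)c1`, differs from compound 1 by methyl in place of hydrogen on an oxygen on an aromatic ring. No measured step touches this oxygen; the one step shown, a number 4 percentage points higher from compound 1 to compound 2 (within the scatter), concerns a different part of the molecule and stayed within the scatter. Nothing shown therefore supports a move beyond the scatter, and the expected step is a number 1 percentage points lower from compound 1 to compound 3 (within the scatter). For compound 3 the estimate in this assay is 101%, with a range from 88% to 114%.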

Compound 3, a percentage reported as activity, at one concentration (the size of the read-out at that concentration, not a potency): 97%
The estimate for compound 3 lay 4 percentage points above the measured number; the range from low to high includes it.
By their numbers in this assay, from the lowest: compounds 3, 1 and 2 (each within the scatter of the next).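

In this assay, going by these compounds alone, the first change at this oxygen, hydroxy to methoxy on the aryl group, gives a number 5 percentage points lower from compound 1 to compound 3 (within the scatter), so the two groups cannot be told apart here. With methyl in place of hydrogen on this oxygen, compound 3 at 97% still sits at a level that shows no effect at the one concentration tested, so this change does not bring out any activity in the series at that concentration. No measurement available here gives a reason for this result.

Going by these compounds, whether an amine or a longer chain such as ethoxy on this aromatic position would move the read-out remains open. On these data alone, since compounds 1, 2 and 3 all sit at the no-effect level, it is also open whether the hydroxy to methoxy change would matter at a concentration where the series shows an effect.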